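A few compounds are considered here, and "the series" means these few. Any claim that something is new, unique, unknown or untested is made for them only; others in the source may bear on it.

The measured compounds:
Compound 1, `CC1=CC[C@@H]([C@@](C)(O)CCCC(C)(C)NC(=S)NN)CC1`: in a functional assay on NCI/ADR cells (Homo sapiens) for cytotoxicity, read by sulforhodamine B assay (on this read-out higher numbers stand for weaker inhibition of growth and lower numbers for stronger inhibition of growth), compound 1 gives 29000 nM.
Compound 2, `CC1=CC[C@@H]([C@@](C)(O)CCCC(C)(C)NC(=S)N/N=C\c2ccccc2)CC1`: in this assay compound 2 gives 23800 nM.
Compound 3, `CC1=CC[C@@H]([C@@](C)(O)CCCC(C)(C)NC(=S)N/N=C\c2cccc(Cl)c2)CC1`: in this assay compound 3 gives 31900 nM.

Compound 3 gives the highest of the three numbers, but its distance to compound 1 and to compound 2 lies within the scatter in each case, so the three compounds cannot be told apart on this read-out. Compound 4, `CC1=CC[C@@H]([C@@](C)(O)CCCC(C)(C)NC(=S)N/N=C(/C)c2ccccc2)CC1`, differs from compound 3 in that (a group of 9 heavy atoms (8 carbon, 1 nitrogen; one six-membered aromatic ring of carbon only) in place of a group of 9 heavy atoms (7 carbon, 1 nitrogen, 1 chlorine; one six-membered aromatic ring of carbon only), on an amide-type nitrogen). The change takes away the chloro and brings in one more carbon on the group that sits on the amide-type nitrogen. The step of a 1.3-fold higher number from compound 2 to compound 3 (0.13 log units; within the scatter) bears on the chloro and was within the scatter; the steps of a 1.2-fold lower number from compound 1 to compound 2 (0.09 log units; within the scatter) and a 1.1-fold higher number from compound 1 to compound 3 (0.04 log units; within the scatter) show that the whole side group, with or without chloro, left the number close to that of compound 1. Within the data shown here, no measured step bears on the added carbon. Compound 4 is therefore expected to show a 1.2-fold lower number from compound 3 to compound 4 (0.07 log units; within the scatter), nothing beyond the scatter. The estimate for compound 4 in this assay is 27000 nM, with a range from 12000 nM to 60000 nM.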

Compound 4, concentration for total growth inhibition: > 100000 nM
Compound 4: a limit, no number; the forecaster's own chance of this, stated with the estimate: 10%; middle value at least 3.7-fold (0.56 log units) away from the limit.
By their numbers in this assay, from the lowest: compounds 2, 1 and 3 (each within the scatter of the next). At a limit, above all of these: compound 4.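

In this assay compound 4 gives > 100000 nM, which is a limit of the assay and not a number. On the amide-type nitrogen whose other neighbour is the thiocarbonyl carbon, the side groups of compound 2 and compound 3 had stayed within the scatter of compound 1, but the group of compound 4, with one more carbon than that of compound 2, shows that this place does respond to a change, with an at least 4.2-fold higher number from compound 2 to compound 4 (0.62 log units; beyond the scatter), an at least 3.1-fold higher number from compound 3 to compound 4 (0.49 log units; beyond the scatter) and an at least 3.4-fold higher number from compound 1 to compound 4 (0.53 log units; beyond the scatter). How large these steps really are stays unknown, because compound 4 sits at a limit: the limit of > 100000 nM in this assay, at which 1 of the 4 values shown sits.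

The compounds shown leave open whether an ethyl group in place of the added carbon would give the same result. They also leave open what a chloro or an amine on the aromatic ring of compound 4 would do.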